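Carboxymethyl replacing carbamoyl on a benzyloxy imidazopyridine

A few compounds are considered here, and "the series" means these few. Any claim that something is new, unique, unknown or untested is made for them only; others in the source may bear on it.

Of the compounds shown here, three built on one shared core have been tested in a functional assay on the whole organism with Rattus norvegicus as the target, with a stated time of 4 h, at a dose of 40 mg/kg by the intraperitoneal route; on this read-out lower numbers stand for less inhibition and higher numbers for more inhibition at the one dose given (going by the name of the read-out). Compound 1 `Cc1cn2cccc(OCc3ccccc3)c2n1` carries only hydrogen at the position of interest and gives 62%. Compound 2 `Cc1nc2c(OCc3ccccc3)cccn2c1C(N)=O` carries a carbamoyl group there and gives 42%; compound 3 `Cc1nc2c(OCc3ccccc3)cccn2c1C#N` carries a cyano group and gives 25%. On these three numbers compound 2 stands second highest, with compound 1 above it and compound 3 below it.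

Compound 4 `Cc1nc2c(OCc3ccccc3)cccn2c1CC(=O)O` has not yet been measured. It differs from compound 2 by a single change: carboxymethyl in place of carbamoyl on an aromatic carbon.

Among the compounds with values here, two measured steps bear on this change. Adding carbamoyl gave a number 20 percentage points lower from compound 1 to compound 2 (beyond the scatter), and swapping that carbamoyl for cyano gave a number 17 percentage points lower from compound 2 to compound 3 (beyond the scatter), so every substituent placed at this position so far has lowered inhibition in this assay. Carboxymethyl is a further substituent at the same place, carrying one donor and one acceptor as the carbamoyl does, so a modest drop or no change beyond the scatter is expected, a number 7 percentage points lower from compound 2 to compound 4 (within the scatter). Compound 4 is therefore estimated at 35%, within a range from 15% to 55%.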

Compound 4, a percentage reported as inhibition, in the whole organism at one dose (the size of the read-out at that dose, not a potency): 12%
Estimate against measurement, compound 4: 23 percentage points above, and the stated range ends above it.
By their numbers in this assay, from the lowest: compound 4; then compound 3; then compound 2; then compound 1.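

In this assay, within the data shown here, this position proves more sensitive to the choice of group than the earlier compounds showed: carboxymethyl in place of carbamoyl gives a number 30 percentage points lower from compound 2 to compound 4 (beyond the scatter) even though both groups have the same counts of hydrogen-bond donors and acceptors, so those counts alone do not set the number here. Carboxymethyl also sits lower than cyano, with a number 13 percentage points lower from compound 3 to compound 4 (beyond the scatter) on that swap, and against plain hydrogen the change is a number 50 percentage points lower from compound 1 to compound 4 (beyond the scatter) in all, so each of the three groups shown gives less inhibition than hydrogen, with no exception among these four compounds. Nothing available here explains why carboxymethyl lowers the number this far.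

The compounds shown leave open whether the chain or its acid end drives this result. A carboxylic acid set directly on the ring, or a carbamoylmethyl chain, would help to separate the two.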